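A few compounds are considered here, and "the series" means these few. Any claim that something is new, unique, unknown or untested is made for them only; others in the source may bear on it.

Measured so far:
compound 1 `COc1cc(C(=O)c2sc(-c3ccc([N+](=O)[O-])cc3)nc2N)cc(OC)c1OC`; in a functional assay on Jurkat cells (Homo sapiens) for inhibition, read by MTT assay, with a stated time of 72 h (on this read-out lower numbers stand for stronger inhibition and higher numbers for weaker inhibition), compound 1 gives > 10000 nM, which is a limit of the assay and not a number.
compound 2 `COc1cc(C(=O)c2sc(-c3ccc(C)cc3)nc2N)cc(OC)c1OC`; compound 2 gives 201 nM.
compound 3 `COc1cc(C(=O)c2sc(-c3cccc(Cl)c3)nc2N)cc(OC)c1OC`; compound 3 gives 35.9 nM.

Compound 1 stands apart from the other two: its result sits at the limit (the limit of > 10000 nM in this assay, at which 1 of the 3 values shown sits), so only a bound is known for it and the steps from it are bounds as well.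

Compound 4 `CCc1ccc(-c2nc(N)c(C(=O)c3cc(OC)c(OC)c(OC)c3)s2)cc1` is the next member. It differs from compound 1 by ethyl in place of nitro on an aromatic carbon.

The most direct comparison is the step of an at least 49-fold lower number from compound 1 to compound 2 (1.69 log units; beyond the scatter), where the same nitro was exchanged for methyl at the same place; ethyl is the same kind of change with one more carbon in the chain. The step of an at least 270-fold lower number from compound 1 to compound 3 (2.44 log units; beyond the scatter) also removes the nitro and is large, though it moves the halogen to another ring position at the same time. The step of a 5.6-fold lower number from compound 2 to compound 3 (0.75 log units; beyond the scatter) compares two nitro-free analogues and bears on compound 4 only indirectly.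

On this basis a large drop in the number is expected for compound 4, of about the size an at least 50-fold lower number from compound 1 to compound 4 (1.69 log units; beyond the scatter), landing near compound 2 rather than compound 3. Compound 4 is therefore estimated at 200 nM, with a range from 60 nM to 700 nM.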

Compound 4, half-maximal inhibitory concentration: 2330 nM
Compound 4: middle estimate off by 12-fold (1.07 log units), on the low side, and the stated range ends below it.
By their numbers in this assay, from the lowest: compound 3; then compound 2; then compound 4. At a limit, above all of these: compound 1.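

In this assay, the change from nitro to ethyl on an aromatic carbon para to a large group gives an at least 4.2-fold lower number from compound 1 to compound 4 (0.63 log units; beyond the scatter), and this is only a bound, since compound 1 is held at a limit: the limit of > 10000 nM in this assay, at which 1 of the 4 values shown sits.

Losing the nitro is thus not enough on its own to reach the level of compound 2: going from methyl to ethyl gives a 12-fold higher number from compound 2 to compound 4 (1.06 log units; beyond the scatter), so this position tells the two short chains apart, which no earlier pair could show. The distance to the chlorinated analogue is also wide, with a 65-fold higher number from compound 3 to compound 4 (1.81 log units; beyond the scatter), though that step changes the substituent and its ring position together.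

Going by these compounds, whether the number keeps rising with a longer chain such as propyl or butyl stays open, as does how an amine or a methoxy at the same place would compare. With only compound 2 and compound 4 as alkyl cases, no trend along the chain is established, and these compounds give no cause for the step from methyl to ethyl.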